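The compounds below may be only part of what the source reports. "The series", "measured", "known", "first", "only" and "open" are said of these compounds alone.

Measured so far:
compound 1, `CN(C)c1ncnc2c1c(-c1ccsc1)cn2[C@@H]1O[C@H](CO)[C@@H](O)[C@H]1O` — 1920 nM
compound 2, `Cc1ncnc2c1c(I)cn2[C@@H]1O[C@H](CO)[C@@H](O)[C@H]1O` — 2650 nM

In a functional assay on HL-60 cells (Homo sapiens) for antiproliferative activity, read by XTT assay, with a stated time of 72 h (a lower number here means a stronger inhibitor, a higher number a weaker inhibitor), compound 1 gives 1920 nM and compound 2 gives 2650 nM, two numbers that lie within the usual scatter of each other, so neither compound can be called the stronger one. Compound 3, `Cc1ncnc2c1c(-c1cccs1)cn2[C@@H]1O[C@H](CO)[C@@H](O)[C@H]1O`, is not yet measured. It differs from compound 2 in one place: thiophen-2-yl in place of iodo on an aromatic carbon. Going by the values given here, no measured pair shows this exchange, so there is no step to lean on. Compound 3 is expected to come out at 1800 nM, with a plausible range from 500 nM to 6000 nM. That expectation means a step of a 1.5-fold lower number from compound 2 to compound 3 (0.17 log units; within the scatter), no larger than the scatter.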

Compound 3, half-maximal inhibitory concentration: 5730 nM
For compound 3 the middle estimate is 3.2-fold (0.50 log units) below the measured one; the measured number falls inside the stated range.
By their numbers in this assay, from the lowest: compounds 1 and 2 (each within the scatter of the next); then compound 3.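

In this assay, replacing the single iodo atom on this aromatic carbon with a thiophen-2-yl ring gives a 2.2-fold higher number from compound 2 to compound 3 (0.33 log units; beyond the scatter) and so costs some activity. Going by these compounds alone, this is a modest change, but it is the first one here that stands clear of the scatter, so the group at this position does influence the read-out. A five-membered aromatic ring is tolerated here, yet on the methyl-bearing core it does not improve on iodo.

Going by these compounds, whether a phenyl ring or an amine on this carbon would give a lower number remains open. Nothing measured here explains the step.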